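Benzothiazol-2-yl replacing phenyl on the amide nitrogen

The source may hold more compounds than are shown below. What is called first, only, known or untested is meant among the compounds shown, and "the series" means these compounds.

Compound 1 `O=C(CCCCCCNC(=O)C(O)(O)C(F)(F)F)Nc1ccccc1` carries a phenyl on the amide-type nitrogen. In a functional assay on HCT-116 cells (Homo sapiens) for inhibition, read by colorimetric assay, with a stated time of 3 days (a higher number here means a weaker inhibitor, a lower number a stronger inhibitor), compound 1 gives 9140 nM, the highest of the two numbers in the series. Compound 2 `O=C(CCCCCCNC(=O)C(O)(O)C(F)(F)F)Nc1ccc(-c2ccccc2)cc1` gives 4730 nM, and the step of a 1.9-fold lower number from compound 1 to compound 2 (0.29 log units; within the scatter). Compound 3 `C/C(=N\O)C(=O)NCCCCCCC(=O)Nc1ccccc1` gives only a limit of the assay, > 100000 nM, which is the limit of > 100000 nM in this assay, at which 1 of the 3 values shown sits. The step of an at least 10-fold higher number from compound 1 to compound 3 (1.03 log units; beyond the scatter) and concerns the other end of the chain.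

Compound 4 `O=C(CCCCCCNC(=O)C(O)(O)C(F)(F)F)Nc1nc2ccccc2s1` is not yet measured. (1,3-benzothiazol-2-yl in place of phenyl on an amide-type nitrogen). Among the compounds with values here, of the measured steps, only that from compound 1 to compound 2, which also changes the group on the amide-type nitrogen, bears on this change, and it stayed within the scatter; the step to compound 3 does not bear on the nitrogen substituent. No step beyond the scatter is therefore expected here. Compound 4 is estimated at 6500 nM, within 2500 nM to 17000 nM. The expected step is a 1.4-fold lower number from compound 1 to compound 4 (0.15 log units; within the scatter).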

Compound 4, half-maximal inhibitory concentration: 2370 nM
Beside the measured number, compound 4's estimate is 2.7-fold (0.44 log units) above it; measured number outside the range, below it.
By their numbers in this assay, from the lowest: compounds 4, 2 and 1 (each within the scatter of the next, the first and the last beyond it). At a limit, above all of these: compound 3.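

In this assay, a 3.9-fold lower number from compound 1 to compound 4 (0.59 log units; beyond the scatter) shows that the group on the amide-type nitrogen can move the number beyond the scatter, which the earlier change there, to compound 2, did not. This change replaces the phenyl with 1,3-benzothiazol-2-yl, adding a five-membered aromatic ring with 2 hetero atoms and 2 hydrogen-bond acceptors. Compound 4 and compound 2 lie within the scatter of each other, so two different groups on this nitrogen are not separated in this assay, although only compound 4 is beyond the scatter from compound 1.

Open, as far as these compounds go, is whether the sulfur matters, which a 1,3-benzoxazol-2-yl in place of 1,3-benzothiazol-2-yl would test. Also open, from the compounds shown here alone, is how an amine or carboxylic acid on that ring system, or a longer chain, would read. The data shown give no measured basis for a cause of the step to compound 4.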